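Arylsulfonyl versus benzyl on the ring amine

A few compounds are considered here, and "the series" means these few. Any claim that something is new, unique, unknown or untested is made for them only; others in the source may bear on it.

Compound 1 `COC(=O)c1ccc(C2SCC(=O)N2c2ccc(N3CCN(Cc4cccc(C)c4)CC3)cn2)c(OC)c1` carries a 3-methylbenzyl group on the ring amine of the shared core, and in a functional assay on NALM-6 cells (Homo sapiens) for antiproliferative activity, read by MTT assay and trypan blue exclusion, with a stated time of 72 h (a lower number here means a stronger inhibitor, a higher number a weaker inhibitor), compound 1 gives 27300 nM. Among the numbers shown it stands highest of two: compound 3 `COC(=O)c1ccc(C2SCC(=O)N2c2ccc(N3CCNCC3)cn2)c(OC)c1`, with hydrogen on that nitrogen, gives 9710 nM, the step being a 2.8-fold lower number from compound 1 to compound 3 (0.45 log units; beyond the scatter). Compound 2 `COC(=O)c1ccc(C2SCC(=O)N2c2ccc(N3CCN(S(=O)(=O)c4ccc(F)cc4)CC3)cn2)c(OC)c1` reaches only a limit of the assay, > 100000 nM. Accordingly the step of an at least 3.6-fold higher number from compound 1 to compound 2 (0.56 log units; beyond the scatter) is known only as a floor, as is an at least 10-fold lower number from compound 2 to compound 3 (1.01 log units; beyond the scatter).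

Compound 4 `COC(=O)c1ccc(C2SCC(=O)N2c2ccc(N3CCN(S(=O)(=O)c4ccc([N+](=O)[O-])cc4)CC3)cn2)c(OC)c1` differs from compound 1 by (4-nitrophenyl)sulfonyl in place of 3-methylbenzyl on an amine nitrogen in a ring. For the measured compounds named here, the measured step that bears most directly on it is the one to compound 2, where an arylsulfonyl likewise replaced the 3-methylbenzyl and the number moved to the limit (the limit of > 100000 nM in this assay, at which 1 of the 3 values shown sits); the step to compound 3 points the other way but concerns removal of the group, not its replacement. A (4-nitrophenyl)sulfonyl is therefore expected to behave much as the (4-fluorophenyl)sulfonyl did, with the number rising, a 3.7-fold higher number from compound 1 to compound 4 (0.56 log units; beyond the scatter), and quite possibly only a limit being reported. Compound 4 in this assay is estimated at 100000 nM, with a range of 30000 nM to 300000 nM.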

Compound 4, half-maximal inhibitory concentration: > 100000 nM
Compound 4: only a limit was reported (the forecaster's own chance of this, stated with the estimate: 60%); the middle value sits exactly at the limit.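

In this assay a second arylsulfonyl on the ring amine gives the same outcome as the first, so the result no longer rests on a single compound: the step of an at least 3.6-fold higher number from compound 1 to compound 4 (0.56 log units; beyond the scatter) is known only as a floor, and so is the step of an at least 10-fold higher number from compound 3 to compound 4 (1.01 log units; beyond the scatter) on the side of the free ring amine. Within these four compounds, both arylsulfonyl compounds, compound 2 and compound 4, therefore stand on the high-number side of the 3-methylbenzyl of compound 1 and the hydrogen of compound 3, and nitro in place of fluoro on the aromatic ring does not bring the number back from the limit. The step between compound 2 and compound 4 cannot be read, and no order of nitro and fluoro can be given, as each of these compounds gives only a limit: the limit of > 100000 nM in this assay, at which 2 of the 4 values shown sit.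

On these data alone, whether the sulfonyl link or the aryl group goes with the loss stays open, and a methanesulfonyl or an acetyl on the ring amine would separate the two. A plain methyl or an unsubstituted benzyl on that nitrogen would show whether any group there can match the hydrogen of compound 3.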